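A few compounds are considered here, and "the series" means these few. Any claim that something is new, unique, unknown or untested is made for them only; others in the source may bear on it.

Compound 2 `O=C(Nc1ccccc1O)C1c2ccccc2CCN1C(=O)c1ccc(Cl)cc1` has been tested in a functional assay on NUGC-3 cells (Homo sapiens) for inhibition, read by sulforhodamine B assay, with a stated time of 48 h; a higher number here means a weaker inhibitor of growth, a lower number a stronger inhibitor of growth. In this assay compound 2 gives > 10000 nM, which is a limit of the assay rather than a number. Compound 3 `O=C(Nc1ccccc1O)C1NCCc2ccccc21` likewise gives > 10000 nM, a limit. Compound 1 `O=C(Nc1cccc(C(F)(F)F)c1)C1NCCc2ccccc21` gives > 10000 nM, again a limit. For the measured compounds named here, the one measured change, hydrogen in place of (4-chlorophenyl)carbonyl on an amine nitrogen in a ring, is a step that the two limits leave unreadable from compound 2 to compound 3, because the limit of > 10000 nM in this assay, at which 3 of the 3 values shown sit, leaves its size unreadable. Compound 4 `O=C(Nc1ccc(C(F)(F)F)cc1)C1c2ccccc2CCN1C(=O)c1ccc(Cl)cc1` differs from compound 2 by 4-(trifluoromethyl)phenyl in place of 2-hydroxyphenyl on an amide-type nitrogen. Going by the values given here, no measured step covers this change, so the expectation rests on the limits alone. Compound 4 is estimated to give 15000 nM in this assay, within 4000 nM to 60000 nM. The expected step is therefore a step that the limit leaves unreadable from compound 2 to compound 4, a change not expected to be readable.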

Compound 4, concentration for 50% growth inhibition: 4200 nM
Estimate against measurement, compound 4: 3.6-fold (0.55 log units) above; the measured number falls inside the stated range.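

On the amide-type nitrogen, 4-(trifluoromethyl)phenyl in place of 2-hydroxyphenyl gives an at least 2.3-fold lower number from compound 2 to compound 4 (0.37 log units; beyond the scatter) in this assay, so this position can change growth inhibition. Among the compounds shown, only compound 4 gives a number rather than a limit. The full size of the step stays unknown because compound 2 gives only a limit: the limit of > 10000 nM in this assay, at which 3 of the 4 values shown sit.

The compounds shown leave open whether the gain follows from losing the hydroxyl or from adding trifluoromethyl. On these data alone, how a plain phenyl or a phenyl carrying a nitrile or an amine would behave at this position also remains open.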